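The source may report more compounds than this note shows. Statements on the series, on what has been measured and on what is new or still open speak of the compounds shown alone.

Measured so far:

- compound 1, `Cn1c(Sc2c(F)cc(C(=O)NO)cc2F)nnc1-c1ncccc1F`, in an ADME assay on a cell-free system (plasma, Rattus norvegicus) for metabolic stability, read by LC-MS, with a stated time of 4 h, tested at 100 uM (a lower number here means that less of the compound is left, a higher number that more of the compound is left), gives 100%
- compound 2, `Cn1c(Sc2c(F)cc(C(=O)NO)cc2F)nnc1-c1ccc(CN2CCCCC2)cc1`, in this assay gives 75%
- compound 3, `O=C(NO)c1ccc(Cn2nnc(-c3ncccn3)n2)cc1`, in this assay gives 99%

Among these three numbers compound 1 shows the highest reading, yet the reading of compound 3 sits within the usual scatter of it, so the two cannot be told apart. Only compound 2 stands apart, its number lying beyond the scatter below that of compound 1. No step between a pair of these compounds that differ in a single place has been recorded, so the account can only note what the values themselves show.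

The next compound, compound 4, `Cn1c(Sc2c(F)cc(C(=O)NO)cc2F)nnc1-c1cccs1`, shares the core of compound 1 and differs from it in one place: thiophen-2-yl in place of 3-fluoropyridin-2-yl on an aromatic carbon. The two measured compounds that keep this core, compound 1 and compound 2, carry different groups at this position and give readings that differ beyond the scatter, so the position matters in this assay at least for some groups. Compound 3, with another core, gives a reading close to that of compound 1.

For compound 4 the step of a number 7 percentage points lower from compound 1 to compound 4 (within the scatter) is expected to be small, within the scatter or a little below it. Compound 4 is therefore estimated at 93%, with a range from 78% to 100%.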

Compound 4, percent of the compound remaining: 87%
Estimate against measurement, compound 4: 6 percentage points above, within the range that was stated.
By their numbers in this assay, from the lowest: compound 2; then compound 4; then compounds 3 and 1 (each within the scatter of the next).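

The change from 3-fluoropyridin-2-yl to thiophen-2-yl in this assay gives a number 13 percentage points lower from compound 1 to compound 4 (beyond the scatter), so this position now has a recorded single-place step, and that step lies beyond the scatter even though it is modest. Both groups are single aromatic rings with no net charge and the same counts of hydrogen-bond donors and acceptors, so a change at this position need not bring in a basic-looking side chain such as the piperidinylmethyl-bearing phenyl group of compound 2 for the reading to move, although compound 4 at 87% still stands above compound 2 at 75%. Nothing measured on these compounds accounts for the step, so the reason for it remains unknown.

The compounds shown do not separate the parts of this change, namely the ring size, the ring sulfur and the loss of the fluorine, and a pyridin-2-yl group without fluorine or a furan-2-yl group would bear on that question. They also leave open how a plain phenyl group or a phenyl group carrying a simple amine would read at this position on the shared core.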